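Aryl-substituted series: chloro analogue in the cytotoxicity assay

This account rests on a few compounds, and the source may have more. Where it says the series, first, only, none or still open, it means among the compounds named here.

Measured so far, in a functional assay on DU-145 cells (Homo sapiens) for cytotoxicity, read by MTT assay; a lower number here means a stronger inhibitor, a higher number a weaker inhibitor:
- compound 1 `c1ccc(-c2nnc(-c3c[nH]c4ccccc34)o2)cc1` gives > 1000000 nM, a limit of the assay.
- compound 2 `c1ccc(Cc2nnc(-c3c[nH]c4ccccc34)o2)cc1` gives > 1000000 nM, also a limit.
- compound 3 `COc1ccc(-c2nnc(-c3c[nH]c4ccccc34)o2)cc1` gives > 1000000 nM, again a limit.

Compound 3 thus stands at the limit of this assay, as do the other two compounds (the limit of > 1000000 nM in this assay, at which 3 of the 3 values shown sit). Neither of the two measured steps reads as a number: benzyl in place of phenyl on an aromatic carbon gives a step that the two limits leave unreadable from compound 1 to compound 2, and methoxy in place of hydrogen on an aromatic carbon gives a step that the two limits leave unreadable from compound 1 to compound 3.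

Compound 4 `Clc1ccc(-c2nnc(-c3c[nH]c4ccccc34)o2)cc1` differs from compound 3 by chloro in place of methoxy on an aromatic carbon. No measured step bears directly on this exchange; what is shown is that every change tried so far on the shared core has left the value at the limit. Compound 4 is therefore expected to stay there as well, with an estimated step of a number no higher from compound 3 to compound 4 (the limit leaves the size open). The estimate for compound 4 in this assay is 1000000 nM, expected to lie between 200000 nM and 5000000 nM, most likely again reported only as a limit.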

Compound 4, half-maximal inhibitory concentration: 192000 nM
The estimate for compound 4 lay 5.2-fold (0.72 log units) above the measured number; the measured number lies below the stated range.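

In this assay, the position para to a large group can move the read-out after all: chloro in place of hydrogen gives an at least 5.2-fold lower number from compound 1 to compound 4 (0.71 log units; beyond the scatter). Occupying the position is not enough, and the identity of the group counts: chloro in place of methoxy gives an at least 5.2-fold lower number from compound 3 to compound 4 (0.71 log units; beyond the scatter), while 4-chlorophenyl in place of benzyl gives an at least 5.2-fold lower number from compound 2 to compound 4 (0.71 log units; beyond the scatter). Compound 4 is the only compound shown that comes off the limit, and compound 1, compound 2 and compound 3 remain there: the limit of > 1000000 nM in this assay, at which 3 of the 4 values shown sit.

On these data alone, the true size of each step stays open, as each one starts from a limit and not from a number. Also open, as far as these compounds go, is whether bromo, trifluoromethyl or an amine at this same position would leave the limit as chloro does, and how far the value could fall.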